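The source may hold more compounds than are shown below. What is called first, only, known or untested is meant among the compounds shown, and "the series" means these compounds.

Compound 1 `O=C(NCc1ccc(C(F)(F)F)nc1N1CCCCC1)Nc1cccc2[nH]c(=O)ccc12`, which in an assay on HEK cells for antagonist activity at transient receptor potential cation channel subfamily V member 1 (Homo sapiens), read by FLIPR (a higher number here means a weaker inhibitor, a lower number a stronger inhibitor), gives 0.75 nM.
Compound 2 `CCCCCOc1nc(C(F)(F)F)ccc1CNC(=O)Nc1cccc2[nH]c(=O)ccc12`, which in this assay gives 2.72 nM.
Compound 3 `O=C(NCc1ccc(C(F)(F)F)nc1OCC1CCC1)Nc1cccc2[nH]c(=O)ccc12`, which in this assay gives 1.49 nM.

Compound 1 holds the lowest number of the three in this assay. Against compound 3 the gap is a 2.0-fold higher number from compound 1 to compound 3 (0.30 log units; within the scatter), which does not set the two apart; against compound 2 it is a 3.6-fold higher number from compound 1 to compound 2 (0.56 log units; beyond the scatter), a modest step that does. Between compound 2 and compound 3 the step is a 1.8-fold lower number from compound 2 to compound 3 (0.26 log units; within the scatter).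

Compound 4 `CC(C)c1cccc(-c2nc(C(F)(F)F)ccc2CNC(=O)Nc2cccc3[nH]c(=O)ccc23)c1` has not yet been measured. It differs from compound 1 in one place: 3-isopropylphenyl in place of piperidin-1-yl on an aromatic carbon. Both measured steps away from compound 1 replace the same piperidin-1-yl and both move the number upward, one of them beyond the scatter, so they bear on this step; neither, however, puts an aromatic ring in that place, so the size of the step for 3-isopropylphenyl cannot be read directly from them. On the strength of those two steps, compound 4 is expected to land somewhat above compound 1 in this assay, with a step of about a 2.7-fold higher number from compound 1 to compound 4 (0.43 log units; beyond the scatter), the direction uncertain within the scatter. The estimate for compound 4 is 2 nM, expected to fall between 0.6 nM and 8 nM.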

Compound 4, half-maximal inhibitory concentration: 1.35 nM
Estimate against measurement, compound 4: 1.5-fold (0.17 log units) above; measured number inside the range.
By their numbers in this assay, from the lowest: compounds 1, 4, 3 and 2 (each within the scatter of the next, the first and the last beyond it).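

In this assay, the place next to the ring nitrogen accepts a carbon-only aromatic ring: 3-isopropylphenyl is not set apart from piperidin-1-yl by a 1.8-fold higher number from compound 1 to compound 4 (0.26 log units; within the scatter), nor from the two ethers by a 1.1-fold lower number from compound 3 to compound 4 (0.04 log units; within the scatter) and a 2.0-fold lower number from compound 2 to compound 4 (0.30 log units; within the scatter), all three steps lying within the scatter. The earlier compounds shown here carried only non-aromatic groups here, bound through nitrogen or oxygen, whereas compound 4 shows that an aromatic ring bound directly through carbon, with no hydrogen-bond acceptor in the entering group, also keeps the number in the same low range. Nothing among the data shown explains why these different groups give such close values.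

As far as these compounds go, what a plain phenyl would give in this place remains open, so the contribution of the isopropyl group to the value of compound 4 cannot be separated from that of the ring. Also open is how the number would respond to a carboxylic acid or a primary amine here, as all four groups shown carry no net charge and no hydrogen-bond donor.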